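Moving a methoxy group: what compound 3 may show

This account rests on a few compounds, and the source may have more. Where it says the series, first, only, none or still open, it means among the compounds named here.

In an ADME assay on CCRF-CEM cells (Homo sapiens) for antiproliferative activity, with a stated time of 48 h (on this read-out lower numbers stand for stronger inhibition and higher numbers for weaker inhibition), compound 1 `C=C(Br)C(=O)Nc1ccc(/C=C/C(=O)c2ccc(Br)cc2)cc1` gives 990 nM and compound 2 `C=C(Br)C(=O)Nc1ccc(/C=C/C(=O)c2ccc(OC)cc2)cc1` gives 1400 nM. For the measured compounds named here, these are the only two numbers so far, and they lie within the usual scatter of each other, so compound 2 cannot be ranked apart from compound 1. Compound 3 `C=C(Br)C(=O)Nc1ccc(/C=C/C(=O)c2cccc(OC)c2)cc1` keeps the shared core and differs from compound 2 in one place: 3-methoxyphenyl in place of 4-methoxyphenyl on a carbonyl carbon. Going by the values given here, the one measured step that bears on this, a 1.4-fold higher number from compound 1 to compound 2 (0.15 log units; within the scatter), put methoxy in place of bromo on an aromatic carbon. Among the compounds with values here, that is a different change, so it is only a loose guide, and no measured pair shows what this move does. No step beyond the scatter is therefore expected in this assay, and no direction can be argued. The expected step is a 1.1-fold lower number from compound 2 to compound 3 (0.03 log units; within the scatter). Compound 3 is estimated at 1300 nM, with a range of 600 nM to 3000 nM.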

Compound 3, half-maximal inhibitory concentration: 2300 nM
Beside the measured number, compound 3's estimate is 1.8-fold (0.25 log units) below it; the range from low to high includes it.
By their numbers in this assay, from the lowest: compounds 1, 2 and 3 (each within the scatter of the next, the first and the last beyond it).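

Swapping 4-methoxyphenyl for 3-methoxyphenyl on the carbonyl carbon gives a 1.6-fold higher number from compound 2 to compound 3 (0.22 log units; within the scatter) in this assay, so this shift of the methoxy group does not clearly separate the two compounds. Replacing 4-bromophenyl with 3-methoxyphenyl at the same place gives a 2.3-fold higher number from compound 1 to compound 3 (0.37 log units; beyond the scatter), a modest step but the first here to pass the usual scatter, and it changes both the group and where the group sits on the ring, so the two changes cannot be told apart. Nothing available explains these numbers.

A 3-bromophenyl group at this place would show how much of that step comes from the group and how much from its place on the ring. On these data alone, whether an amine or a carboxylic acid on this ring would move the numbers further also stays open.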